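Swapping the Sulfonyl Aryl Group from Compound 3 to Compound 4

A few compounds are considered here, and "the series" means these few. Any claim that something is new, unique, unknown or untested is made for them only; others in the source may bear on it.

Three compounds sharing one core have been examined in an assay on isolated protein for inhibition of malate dehydrogenase, mitochondrial (Sus scrofa), with stated times of 45 min and 30 min; a lower number here means a stronger inhibitor, a higher number a weaker inhibitor. Compound 1 `O=S(=O)(Nc1ccc(-c2nc3ccccc3o2)cc1)c1ccccc1Cl` carries a 2-chlorophenyl on the sulfonyl sulfur; in this assay compound 1 gives only a limit, > 63000 nM. Compound 2 `O=S(=O)(Nc1ccc(-c2nc3ccccc3o2)cc1)c1cccs1` carries a thiophen-2-yl there, and in this assay compound 2 likewise reaches only a limit, > 63000 nM. Compound 3 `COc1ccc(S(=O)(=O)Nc2ccc(-c3nc4ccccc4o3)cc2)cc1` carries a 4-methoxyphenyl, and in this assay compound 3 also stops at a limit, > 63000 nM. The steps a step that the two limits leave unreadable from compound 1 to compound 2, a step that the two limits leave unreadable from compound 1 to compound 3 and a step that the two limits leave unreadable from compound 2 to compound 3 therefore cannot be sized, a consequence of the limit of > 63000 nM in this assay, at which 3 of the 3 values shown sit.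

Compound 4 `Cc1cccc(S(=O)(=O)Nc2ccc(-c3nc4ccccc4o3)cc2)c1` differs from compound 3 by one change: 3-methylphenyl in place of 4-methoxyphenyl on a sulfonyl sulfur. Every measured step on this sulfonyl sulfur is unreadable, so no direction or size of step in this assay can be drawn from them. Given that compound 3 sits at > 63000 nM, compound 4 is expected to give 90000 nM, with a range from 30000 nM to 300000 nM, and the expected step that the limit leaves unreadable from compound 3 to compound 4 most likely remains a limit rather than a number.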

Compound 4, half-maximal inhibitory concentration: > 63000 nM
Compound 4 gave a limit, no number; the forecaster's own chance of this, stated with the estimate: 85%; the middle value is on the limit's open side.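

No step to compound 4 from compound 1, compound 2 or compound 3 can be read, and all of them stay unsized because of one shared limit: the limit of > 63000 nM in this assay, at which 4 of the 4 values shown sit.

The compounds shown leave open whether any of these groups on the sulfonyl sulfur alters inhibition in this assay, and what number each compound would actually give.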